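Lengthening the chain on compound 3 by one carbon

The compounds below may be only part of what the source reports. "The series", "measured", "known", "first", "only" and "open" are said of these compounds alone.

Measured so far:
compound 1, `CCOC(=O)Nc1cccc2c1CN(C)CC2c1ccccc1`: 2.5 mg/kg
compound 2, `CCCCOC(=O)Nc1cccc2c1CN(C)CC2c1ccccc1`: 12 mg/kg
compound 3, `CC(C)NCC(=O)Nc1cccc2c1CN(C)CC2c1ccccc1`: about 30 mg/kg

All three values come from a functional assay on the whole organism for inhibition of sodium-dependent dopamine transporter (Mus musculus); a lower number here means that less compound is needed, a higher number that more compound is needed for the effect. Compound 3 gives the highest number of the three: the nearest is a 2.5-fold higher number from compound 2 to compound 3 (0.40 log units; beyond the scatter), the furthest is a 12-fold higher number from compound 1 to compound 3 (1.08 log units; beyond the scatter), both beyond the scatter.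

Compound 4, `CC(C)NCCC(=O)Nc1cccc2c1CN(C)CC2c1ccccc1`, has not been measured. It differs from compound 3 only in the chain on the carbonyl carbon: (isopropylamino)methyl in place of isopropylamino on a saturated chain carbon bound to a carbonyl carbon.

The measured step most like this one is a 4.8-fold higher number from compound 1 to compound 2 (0.68 log units; beyond the scatter), where a longer chain on the same side of the shared core gave a modestly higher number. The steps of a 12-fold higher number from compound 1 to compound 3 (1.08 log units; beyond the scatter) and a 2.5-fold higher number from compound 2 to compound 3 (0.40 log units; beyond the scatter) swap the whole group rather than lengthen it, so they bear less on the change here.

A modest rise is therefore expected, a 1.8-fold higher number from compound 3 to compound 4 (0.26 log units; within the scatter), though a result within the scatter of compound 3 would not surprise. Compound 4 is estimated to give 55 mg/kg in this assay, with a likely range from 18 mg/kg to 170 mg/kg.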

Compound 4, dose for half-maximal effect: about 200 mg/kg
The estimate for compound 4 lay 3.6-fold (0.56 log units) below the measured number; measured number outside the range, above it.
By their numbers in this assay, from the lowest: compound 1; then compound 2; then compound 3; then compound 4.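

In this assay, the chain on the carbonyl carbon proves sensitive to a small extension: replacing (isopropylamino)methyl with 2-(isopropylamino)ethyl gives a 6.7-fold higher number from compound 3 to compound 4 (0.82 log units; beyond the scatter), so longer chains raise the number with the amine as well as with the ethoxy-to-butoxy change. The same 2-(isopropylamino)ethyl group also stands far from the two oxygen-linked chains, with a 17-fold higher number from compound 2 to compound 4 (1.22 log units; beyond the scatter) and an 80-fold higher number from compound 1 to compound 4 (1.90 log units; beyond the scatter), and it gives the highest number of the four compounds. No measurement is available to explain why this extension raises the number.

The compounds shown leave open whether a longer chain such as 3-(isopropylamino)propyl would raise the number further. They also leave open whether a dimethylamino group in place of isopropylamino would behave the same way on either chain length.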